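The compounds below may be only part of what the source reports. "The series", "measured", "known", "first", "only" and "open" are said of these compounds alone.

In an ADME assay on HEK-293T cells (Homo sapiens) for inhibition, read by CCK-8 assay, with a stated time of 48 h, tested at 20 uM (on this read-out lower numbers stand for less inhibition of growth and higher numbers for more inhibition of growth at the one concentration tested), three compounds sharing one core have been examined. Compound 1 (`N#C/C(=C\c1ccccc1OS(=O)(=O)c1ccc([N+](=O)[O-])cc1)C(=O)Nc1nnc(Cc2ccc(F)cc2)s1`) gives 8%, and compound 2 (`N#C/C(=C\c1ccccc1OS(=O)(=O)c1ccc(Cl)cc1)C(=O)Nc1nnc(Cc2ccc(F)cc2)s1`) gives 6%. Compound 3 (`N#C/C(=C\c1ccccc1OS(=O)(=O)c1ccc(F)cc1)C(=O)Nc1nnc(Cc2ccc(F)cc2)s1`) is reported only as "not toxic" (no number reported), so it stands without a single number on this scale. Compound 4 (`N#C/C(=C\c1ccccc1OS(=O)(=O)c1ccc(F)cc1)C(=O)Nc1nnc(Cc2ccc(Cl)cc2)s1`) departs from compound 3 in one place, with chloro in place of fluoro on an aromatic carbon, para to a large group, turning 4-fluorobenzyl into 4-chlorobenzyl: chloro in place of fluoro on an aromatic carbon. Among the compounds with values here, the one measured step that bears on this is a number 2 percentage points lower from compound 1 to compound 2 (within the scatter). It is a different exchange, chloro in place of nitro on an aromatic carbon, made elsewhere in the molecule, so it offers only indirect guidance. On that evidence, no step beyond the scatter is expected in this assay in either direction. With no number for compound 3, the expectation rests on compound 1 at 8% and compound 2 at 6%. Compound 4 is estimated at 7%, with an expected range of 0% to 20%.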

Compound 4, percent growth inhibition at one concentration: 14%
Beside the measured number, compound 4's estimate is 7 percentage points below it, and the stated range covers the measured number.
By their numbers in this assay, from the lowest: compounds 2, 1 and 4 (each within the scatter of the next).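

Compound 3 has no number in this assay, so the step from it to compound 4 (14%) cannot be read. The compounds shown leave open how chloro in place of fluoro on the benzyl ring alters growth inhibition. No evidence at hand bears on this result.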